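The source may hold more compounds than are shown below. What is called first, only, known or untested is meant among the compounds shown, and "the series" means these compounds.

Compound 1 `C[Se]/C(=N\C(=O)c1cc2ccccc2s1)NC(=O)c1cc2ccccc2s1` gives 5620 nM
Compound 2 `C[Se]/C(=N\C(=O)c1sccc1Cl)NC(=O)c1sccc1Cl` gives 4.9 nM
Compound 3 `CS/C(=N\C(=O)c1ccco1)NC(=O)c1ccco1` gives 77100 nM

In a functional assay on HT-29 cells (Homo sapiens) for cytotoxicity, read by MTT assay, with a stated time of 72 h (a higher number here means a weaker inhibitor of growth, a lower number a stronger inhibitor of growth), compound 1 stands second highest of the three numbers. Compound 2 sits far lower, beyond the scatter, and compound 3 sits higher, also beyond the scatter; both differ from compound 1 in the aromatic parts and in the atom bound to the methyl group, so no single change among the measured compounds is isolated.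

Compound 4 `O=C(/N=C(/NC(=O)c1cc2ccccc2s1)[Se]Cc1ccccc1)c1cc2ccccc2s1` differs from compound 1 in one place: phenyl in place of hydrogen on a saturated chain carbon bound to a selenium atom. Going by the values given here, no measured pair shows this change, so its size cannot be read from the data at hand. The author expects a modest step in this assay, most likely toward a lower number for compound 4, with a real chance that it stays within the usual scatter around compound 1.

For compound 4 the estimate is 3000 nM, with a range from 600 nM to 15000 nM. This estimate means a step of a 1.9-fold lower number from compound 1 to compound 4 (0.27 log units; within the scatter) for the benzyl in place of the methyl group on selenium.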

Compound 4, concentration for 50% growth inhibition: 6510 nM
For compound 4 the middle estimate is 2.2-fold (0.34 log units) below the measured one; low and high end bracket the measured number.
By their numbers in this assay, from the lowest: compound 2; then compounds 1 and 4 (each within the scatter of the next); then compound 3.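

In this assay, the change from methyl to benzyl gives a 1.2-fold higher number from compound 1 to compound 4 (0.06 log units; within the scatter), the first change in a single place among these compounds. Adding a phenyl on the saturated chain carbon bound to the selenium atom therefore leaves the number within the scatter, and compound 1 and compound 4 cannot be told apart in this assay. At this position on this core, the added six-membered aromatic ring of carbon shows no measurable effect on growth inhibition, and no supporting measurement bears on why that is so.

On these data alone, it remains open whether an amine or a carboxylic acid on that phenyl, or a longer chain between it and the selenium atom, would behave the same way. As far as these compounds go, it is also open whether the same change from methyl to benzyl would leave the number as unmoved on the core of compound 2.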